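The compounds below may be only part of what the source reports. "The series", "measured", "known", "first", "only" and "open" are said of these compounds alone.

Measured compounds in a functional assay on CHO-K1 cells for agonist activity at Glucose-dependent insulinotropic receptor (Homo sapiens), read by a luciferase reporter, with a stated time of 5 h; on this read-out lower numbers stand for an effect already at smaller amounts and higher numbers for an effect only at larger amounts of compound:
- compound 1 `CC(=O)N1CCN(c2ccc(OCC3CCN(C(=O)OC(C)C)CC3)cn2)CC1`: > 10000 nM, a limit of the assay, not a number
- compound 2 `CC(C)OC(=O)N1CCC(COc2ccc(N3CCN(C(=O)c4ccco4)CC3)nc2)CC1`: 1900 nM
- compound 3 `COCCS(=O)(=O)N1CCN(c2ccc(OCC3CCN(C(=O)OC(C)C)CC3)cn2)CC1`: 300 nM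

Compound 3 holds the lowest of the two numbers in this assay; its nearest neighbour is compound 2, with a 6.3-fold lower number from compound 2 to compound 3 (0.80 log units; beyond the scatter). Compound 4 `CC(C)OC(=O)N1CCC(COc2ccc(N3CCN(S(=O)(=O)c4cccnc4)CC3)nc2)CC1` differs from compound 3 by pyridin-3-yl in place of 2-methoxyethyl on a sulfonyl sulfur. All measured steps concern the group on the ring nitrogen: an at least 5.2-fold lower number from compound 1 to compound 2 (0.72 log units; beyond the scatter), an at least 33-fold lower number from compound 1 to compound 3 (1.52 log units; beyond the scatter) and a 6.3-fold lower number from compound 2 to compound 3 (0.80 log units; beyond the scatter), each beyond the scatter, and each favouring the sulfonyl. Among the compounds with values here, none of them alters what sits on the sulfonyl sulfur itself, so the change to compound 4 has no direct precedent here. Compound 4 is therefore expected to stay near compound 3, with a 1.7-fold higher number from compound 3 to compound 4 (0.22 log units; within the scatter) in either direction; the estimate for compound 4 is 500 nM, within 100 nM to 3000 nM.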

Compound 4, half-maximal effective concentration: 2000 nM
Compound 4: middle estimate off by 4.0-fold (0.60 log units), on the low side; low and high end bracket the measured number.
By their numbers in this assay, from the lowest: compound 3; then compounds 2 and 4 (each within the scatter of the next). At a limit, above all of these: compound 1.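

In this assay, the sulfonyl alone does not secure the low number: pyridin-3-yl in place of 2-methoxyethyl on the sulfonyl sulfur gives a 6.7-fold higher number from compound 3 to compound 4 (0.82 log units; beyond the scatter). The group on the sulfur therefore matters, and the advantage of sulfonyl over carbonyl holds only for compound 3, with compound 4 going against it at a 1.1-fold higher number from compound 2 to compound 4 (0.02 log units; within the scatter). The remaining step, an at least 5.0-fold lower number from compound 1 to compound 4 (0.69 log units; beyond the scatter), is read against a limit, not a number: the limit of > 10000 nM in this assay, at which 1 of the 4 values shown sits.

Going by these compounds, it remains open whether a plain phenyl, a simple ethyl or a longer alkoxyalkyl chain on the sulfonyl sulfur would match 2-methoxyethyl. The compounds shown also cannot tell whether the gain lies with the chain or with its ether oxygen.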